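Pyridin-2-yl gives way to 1,3-benzothiazol-2-yl on a sulfur

The source may hold more compounds than are shown below. What is called first, only, known or untested is meant among the compounds shown, and "the series" means these compounds.

In a functional assay on HepG2 cells (Homo sapiens) for cytotoxicity, read by MTT assay, with a stated time of 48 h (a higher number here means a weaker inhibitor, a lower number a stronger inhibitor), compound 1 `CC1=NN(C(=O)CSc2ccccn2)[C@@H](c2cc(Br)cc(Br)c2O)C1` gives 24700 nM and stands among a small group of close values. In this assay compound 2 `O=C(CSCc1ccco1)N1N=C(c2cc3ccccc3oc2=O)C[C@@H]1c1ccccc1C(F)(F)F` gives 18000 nM and compound 3 `O=C(CSc1ccc(Br)cc1)N1N=C(c2cc3ccccc3oc2=O)C[C@@H]1c1ccccc1` gives 14500 nM and these three values lie within the usual scatter of one another, so no order can be read among them.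

Compound 4 `CC1=NN(C(=O)CSc2nc3ccccc3s2)[C@@H](c2cc(Br)cc(Br)c2O)C1` has not yet been measured. It keeps the core of compound 1 and alters one group, as the comparison 1,3-benzothiazol-2-yl in place of pyridin-2-yl on a sulfur shows, with 1,3-benzothiazol-2-yl in place of pyridin-2-yl on a sulfur.

Going by the values given here, no two of the measured compounds differ in one place only, so the data offer no direct precedent for this swap. In this assay no step beyond the scatter is expected, only a slight drift toward a lower number. That expectation rests on the narrow spread of the values, with compound 3 at 14500 nM still within the scatter of compound 1 at 24700 nM in spite of their different structures. The estimate amounts to an expected step of a 1.5-fold lower number from compound 1 to compound 4 (0.16 log units; within the scatter) and nothing larger. For compound 4 the estimated value is 17000 nM with an expected range from 7000 nM to 40000 nM in this measurement.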

Compound 4, half-maximal inhibitory concentration: 8700 nM
Compound 4: the middle estimate sits 2.0-fold (0.29 log units) above what was measured; the range from low to high includes it.
By their numbers in this assay, from the lowest: compounds 4, 3, 2 and 1 (each within the scatter of the next, the first and the last beyond it).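

Going by these compounds alone, the chain on the sulfur of the core of compound 1 is not a silent place: in this assay the change to 1,3-benzothiazol-2-yl gives a 2.8-fold lower number from compound 1 to compound 4 (0.45 log units; beyond the scatter) and so offers the first single-place comparison in this set, one that lies beyond the scatter. The step is modest, but it shows that this position can move the number even though compounds 1, 2 and 3, which differ in many places, stood within the scatter of one another. Nothing available bears on why the number falls with this exchange of a single aromatic ring for a five-membered and a six-membered aromatic ring.

As far as these compounds go, whether 1,3-benzoxazol-2-yl, quinolin-2-yl or a plain phenyl on the same sulfur would go the way of compound 4 remains open, and with it the question of whether the step goes with the ring of carbon only or with the ring sulfur. Also open, from the compounds shown here alone, is whether the same exchange would lower the number on the different cores of compound 2 and compound 3, which carry other groups on their sulfur.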